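The compounds below may be only part of what the source reports. "The series", "measured", "known", "first", "only" and "open" are said of these compounds alone.

Compound 2 `C=C(C)CCC[C@@]1(C)CCC[C@H]2C1=CC[C@H](C)[C@]2(C)C[C@H](O)C1=CC(=O)O[C@@H]1O` gives 13100 nM in a functional assay on HL-60 cells (Homo sapiens) for inhibition (on this read-out lower numbers stand for stronger inhibition and higher numbers for weaker inhibition), within the scatter of compound 1 `C=C(C)CCC[C@]1(C)CCC[C@@H]2C1=CC[C@@H](C)[C@@]2(C)C[C@@H](O)C1=CC(=O)O[C@H]1O` at 7100 nM. Compound 3 `C=C(C)CCC[C@]1(C)CCC[C@@H]2C1=CC[C@@H](C)[C@]2(C)C[C@H](O)C1=CC(=O)OC1O` keeps the same atoms and bonds: the two compounds have the same atoms and bonds; at least one stereo element is drawn with a configuration in one of them and without one in the other: 4 of 6 stereo elements differ; a stereocentre at a saturated ring carbon is drawn R in compound 2 and S in compound 3; a stereocentre at a saturated ring carbon is drawn R in compound 2 and S in compound 3; a stereocentre at a saturated ring carbon is drawn S in compound 2 and R in compound 3; a stereocentre at a saturated ring carbon is drawn S in compound 2 and without a configuration in compound 3. Going by the values given here, one measured step bears on this change, a 1.8-fold higher number from compound 1 to compound 2 (0.27 log units; within the scatter), and it rests on the fact that compounds 1 and 2 differ only in the configuration as drawn: inverting every stereo element stayed within the scatter. No step beyond the scatter is therefore expected in this assay, in either direction. The expected 1.3-fold lower number from compound 2 to compound 3 (0.12 log units; within the scatter) is small. For compound 3 the estimated value is 10000 nM, with an expected range of 4000 nM to 25000 nM.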

Compound 3, half-maximal inhibitory concentration: 1000 nM
Compound 3: the middle estimate sits 10-fold (1.00 log units) above what was measured; measured number outside the range, below it.
By their numbers in this assay, from the lowest: compound 3; then compounds 1 and 2 (each within the scatter of the next).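

In this assay configuration does matter: changing only some stereo elements gives a 13-fold lower number from compound 2 to compound 3 (1.12 log units; beyond the scatter) and a 7.1-fold lower number from compound 1 to compound 3 (0.85 log units; beyond the scatter), whereas the full mirror-image inversion gave only a 1.8-fold higher number from compound 1 to compound 2 (0.27 log units; within the scatter). The relative arrangement of the stereocentres, rather than overall handedness, therefore separates these compounds. This reading carries a caveat: the fact that one of compounds 2 and 3 is drawn with a defined configuration and the other without, at the place where they differ

Which configuration at the undefined ring carbon goes with the lower number stays open, as does which changed stereocentre accounts for the step. Going by these compounds, whether a methyl ether or an acetate in place of a hydroxyl would keep this level is also open.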